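This account rests on a few compounds, and the source may have more. Where it says the series, first, only, none or still open, it means among the compounds named here.

Series notes. Compound 1 `CCOC(=O)c1c(-c2cccc(Oc3ccccc3)c2)[nH]c2cc(OC)c(OC)cc2c1=O` and compound 2 `CCOC(=O)c1c(-c2cccc(Oc3ccccc3)c2)[nH]c2cc(OC)c(F)cc2c1=O` share one core and differ at a single point. In an ADME assay on Raji cells (Homo sapiens) for cytotoxicity, read by luminescence, with a stated time of 72 h (on this read-out higher numbers stand for an effect only at larger amounts of compound and lower numbers for an effect already at smaller amounts), compound 1 gives only a limit of the assay, > 21500 nM. In this assay compound 2 likewise gives only a limit, > 21500 nM. The step that the two limits leave unreadable from compound 1 to compound 2 cannot be read in size, since both values sit at the limit of > 21500 nM in this assay, at which 2 of the 2 values shown sit. Compound 3 `COc1cc2[nH]c(-c3cccc(Oc4ccccc4)c3)c(C(=O)OCCO)c(=O)c2cc1F` differs from compound 2 by hydroxy in place of hydrogen on a saturated chain carbon, two bonds along the chain from an oxygen next to a carbonyl group. For the measured compounds named here, no measured step bears directly on this change, the only measured step is unreadable, and compound 2 itself stands at a limit, so the data give neither a size nor a direction to carry over. Compound 3 is therefore expected to remain near the limit, with an estimated step that the limit leaves unreadable from compound 2 to compound 3 of no more than scatter. The estimate for compound 3 in this assay is 25000 nM, expected between 10000 nM and 60000 nM.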

Compound 3, half-maximal effective concentration in the Raji assay: > 21500 nM
Compound 3 ended at the assay's limit; the forecaster's own chance of this, stated with the estimate: 75%; the middle value is on the limit's open side.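

In the Raji assay compound 3 gives only a limit, > 21500 nM. Compound 2 gives only a limit there too, so no new step can be read between these two compounds: the limit of > 21500 nM in the Raji assay, at which 3 of the 3 values shown sit. In a physicochemical assay for solubility, at pH 7.4 (on this read-out higher numbers stand for higher solubility and lower numbers for lower solubility), compound 2 gives 4300 nM and compound 3 gives 3100 nM, which is a 1.4-fold lower number from compound 2 to compound 3 (0.14 log units; within the scatter). Still open, going by these compounds, is whether any change to the shared core would bring a measurable value in the Raji assay.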